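The compounds below may be only part of what the source reports. "The series", "measured", "known", "first", "only" and "open" are said of these compounds alone.

Measured compounds in a functional assay on DU-145 cells (Homo sapiens) for cytotoxicity, read by sulforhodamine B assay, with a stated time of 48 h; on this read-out higher numbers stand for weaker inhibition of growth and lower numbers for stronger inhibition of growth:
compound 1 `N#Cc1ccc(Nc2nc(Oc3ccnc4ccccc34)nc(N3CCN(c4ccccc4Cl)CC3)n2)cc1C(F)(F)F`: > 100000 nM
compound 2 `CN1CCN(c2nc(Nc3ccc(C#N)c(C(F)(F)F)c3)nc(Oc3ccnc4ccccc34)n2)CC1`: > 100000 nM
compound 3 `N#Cc1ccc(Nc2nc(Oc3ccnc4ccccc34)nc(N3CCN(c4ccccn4)CC3)n2)cc1C(F)(F)F`: > 100000 nM

Each of these values is a limit of this assay, not a number. Compound 2 stands on a limit only, and the two further values shown are limits as well, so none of the three can be placed relative to another. The changes on the amine nitrogen in the ring, a step that the two limits leave unreadable from compound 1 to compound 2, a step that the two limits leave unreadable from compound 1 to compound 3 and a step that the two limits leave unreadable from compound 2 to compound 3, are all unreadable for the same reason: the limit of > 100000 nM in this assay, at which 3 of the 3 values shown sit.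

Compound 4 `COc1ccc(CN2CCN(c3nc(Nc4ccc(C#N)c(C(F)(F)F)c4)nc(Oc4ccnc5ccccc45)n3)CC2)c(OC)c1OC` differs from compound 2 by 2,3,4-trimethoxyphenyl in place of hydrogen on a saturated chain carbon bound to an amine nitrogen in a ring. For the measured compounds named here, no measured step bears directly on this change; the three steps that are known all sit between limits, so they offer no readable size or direction. The only thing the shown compounds say is that every variation tried so far on this nitrogen, whether 2-chlorophenyl, methyl or pyridin-2-yl, leaves growth inhibition beyond the limit of this assay. With no reason to expect otherwise, compound 4 is estimated at 150000 nM, within 30000 nM to 600000 nM, in this assay. The step expected is a step that the limit leaves unreadable from compound 2 to compound 4, most probably reported again as a limit rather than a number.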

Compound 4, concentration for total growth inhibition: > 100000 nM
Compound 4 gave a limit, no number; the forecaster's own chance of this, stated with the estimate: 70%; the middle value lies beyond the limit too.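

No new step can be read: compound 2 and compound 4 both stand on limits, not numbers, so the change between them has no readable size, and the cause is the one already seen: the limit of > 100000 nM in this assay, at which 4 of the 4 values shown sit.

The compounds shown leave open how far any of them lies beyond that limit, and whether any substituent on this ring nitrogen gives a measurable concentration for total growth inhibition.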